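This account rests on a few compounds, and the source may have more. Where it says the series, first, only, none or still open, it means among the compounds named here.

Going by the values given here, in a functional assay on HCT-116 cells (Homo sapiens) for inhibition, read by CCK-8 assay, with a stated time of 48 h (on this read-out higher numbers stand for weaker inhibition and lower numbers for stronger inhibition), only one true number exists so far. Compound 2 `COc1cc(-c2ccnc3cc(-c4ccc(C(C)=O)cc4)nn23)cc(OC)c1OC` gives 4390 nM. Compound 1 `COc1cc(-c2ccnc3cc(-c4cccc(C#N)c4)nn23)cc(OC)c1OC` reaches only a limit of the assay, > 10000 nM, a point also noted in the limit of > 10000 nM in this assay, at which 1 of the 2 values shown sits. Among the compounds with values here, the single measured step is therefore open-ended: an at least 2.2-fold lower number from compound 1 to compound 2 (0.35 log units; beyond the scatter). Within the data shown here, it shows that exchanging the aryl group on the shared core can move the number beyond the scatter, but it is only one step and its true size is unknown.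

Compound 3 `COc1ccc(-c2cc3nccc(-c4cc(OC)c(OC)c(OC)c4)n3n2)cc1F` changes the group at this same place: 3-fluoro-4-methoxyphenyl in place of 4-acetylphenyl on an aromatic carbon. The new group is 3-fluoro-4-methoxyphenyl in place of 4-acetylphenyl, on an aromatic carbon of the five-membered aromatic ring. Among the measured compounds shown here, no measured step covers this particular exchange, so the forecast is loose. Judging from an at least 2.2-fold lower number from compound 1 to compound 2 (0.35 log units; beyond the scatter), a change of at least similar size is expected in this assay, more likely toward a lower number, although a move the other way cannot be excluded. The expected step is a 5.5-fold lower number from compound 2 to compound 3 (0.74 log units; beyond the scatter). For compound 3 the estimated value is 800 nM, within an expected range of 30 nM to 8000 nM.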

Compound 3, half-maximal inhibitory concentration: 2840 nM
Compound 3: the middle estimate sits 3.6-fold (0.55 log units) below what was measured, and the stated range covers the measured number.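

In this assay, putting 3-fluoro-4-methoxyphenyl in place of 4-acetylphenyl gives a 1.5-fold lower number from compound 2 to compound 3 (0.19 log units; within the scatter), so on this position the two groups cannot be told apart, even though the entering group has no double bond outside the aromatic ring and carries a fluorine where the leaving group has none. Going by these compounds alone, compound 3 also separates from compound 1, with an at least 3.5-fold lower number from compound 1 to compound 3 (0.54 log units; beyond the scatter), so a second group now stands beyond the scatter from 3-cyanophenyl, which the single earlier step could not show. Compound 1 sits at a limit of the assay, so the true size of both steps that start from it remains unknown: the limit of > 10000 nM in this assay, at which 1 of the 3 values shown sits.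

The compounds shown leave open whether anything other than a substituted phenyl on this aromatic carbon, such as a pyridine ring, an amine or a carboxylic acid, would bring the number down further. They also leave open what the fluorine and the methoxy group each contribute, since 3-fluoro-4-methoxyphenyl enters as a whole and a plain 4-methoxyphenyl does not appear among them.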